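The source may report more compounds than this note shows. Statements on the series, on what has been measured and on what is new or still open speak of the compounds shown alone.

Compound 1, `CCC(O)c1cc2c(cc1NC(=O)Nc1ccc(Cl)cc1)OCCO2`, and compound 2, `CCC(C)(C)C1CCc2c(sc(NC(=O)Nc3ccc(Cl)cc3)c2C(N)=O)C1`, have both been tested in a functional assay (strain AB) with Danio rerio as the target, read by microscopy, with a stated time of 1 h; on this read-out lower numbers stand for an effect already at smaller amounts and higher numbers for an effect only at larger amounts of compound. For compound 1 the assay returns only a limit, > 25000 nM. For compound 2 it likewise returns only a limit, > 25000 nM. Among the measured compounds shown here, both results therefore sit at the limit of > 25000 nM in this assay, at which 2 of the 2 values shown sit, and no measured step between them can be counted. Compound 3, `NC(=O)c1c(NC(=O)Nc2ccc(Cl)cc2)sc2c1CCCC2`, differs from compound 2 by hydrogen in place of 1,1-dimethylpropyl on a saturated ring carbon. Compound 3 is expected to give about 25000 nM in this assay, within 8000 nM to 80000 nM. The step is estimated as a number no higher from compound 2 to compound 3 (the limit leaves the size open), most probably again only a limit rather than a number.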

Compound 3, half-maximal effective concentration: > 25000 nM
Compound 3: no number, only a limit (the forecaster's own chance of this, stated with the estimate: 80%); the middle value lies on the limit itself.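

Among the compounds shown here, compound 2 and compound 3 both return only a limit in this assay, so no step between them can be read. The compounds shown leave open at what concentration any of them takes effect, and whether the 1,1-dimethylpropyl group changes that.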